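The source may hold more compounds than are shown below. What is called first, only, known or untested is meant among the compounds shown, and "the series" means these compounds.

Working notes on the series.

Compound 3 `COc1cc(-c2cnn3cc(OC)c(-c4cnn(C)c4)nc23)ccn1` gives 43% in an ADME assay on microsomes from liver (Homo sapiens) for metabolic stability, with a stated time of 60 min, tested at 1 uM (on this read-out lower numbers stand for a less stable compound and higher numbers for a more stable compound), and stands highest of the three measured numbers; the nearest is compound 1 `COc1cc(-c2cnn3cc(OC)c(C4CCCC4)nc23)ccn1` with 32%, the furthest compound 2 `COc1cc(-c2cnn3cc(OC)c(C4CCOC4)nc23)ccn1` with 29%. The steps within this set: a number 11 percentage points higher from compound 1 to compound 3 (beyond the scatter); a number 14 percentage points higher from compound 2 to compound 3 (beyond the scatter); and a number 3 percentage points lower from compound 1 to compound 2 (within the scatter).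

Compound 4 `COc1cc(-c2cnn3cc(OC)c([C@H]4COC(C)(C)C4)nc23)ccn1` is not yet measured. Compared with compound 3, the change is a group of 7 heavy atoms (6 carbon, 1 oxygen; one five-membered non-aromatic ring with 1 hetero atom) in place of a group of 6 heavy atoms (4 carbon, 2 nitrogen; one five-membered aromatic ring with 2 hetero atoms), on an aromatic carbon. The entering ring is, like the cyclopentyl of compound 1 and the oxolan-3-yl of compound 2, a five-membered non-aromatic ring on the same aromatic carbon, whereas compound 3 carries the aromatic 1-methyl-1H-pyrazol-4-yl there. Among the compounds with values here, the steps that bear on it therefore run the other way: replacing cyclopentyl or oxolan-3-yl by 1-methyl-1H-pyrazol-4-yl gave modest gains beyond the scatter, while the swap between cyclopentyl and oxolan-3-yl stayed within it. For compound 4 a modest fall in this assay is expected, back toward the numbers of compound 1 and compound 2, as the step of a number 13 percentage points lower from compound 3 to compound 4 (beyond the scatter) indicates. The estimate for compound 4 is 30%, with a range from 18% to 45%.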

Compound 4, percent of the compound remaining: 21%
The estimate for compound 4 lay 9 percentage points above the measured number; the range from low to high includes it.
By their numbers in this assay, from the lowest: compounds 4, 2 and 1 (each within the scatter of the next, the first and the last beyond it); then compound 3.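

In this assay, the group of 7 heavy atoms on this aromatic carbon gives a number 22 percentage points lower from compound 3 to compound 4 (beyond the scatter), so the 1-methyl-1H-pyrazol-4-yl of compound 3 now stands apart from all three five-membered non-aromatic rings shown at this position, each step to them lying beyond the scatter. The non-aromatic rings do not form one uniform group either: the new ring gives a number 8 percentage points lower from compound 2 to compound 4 (within the scatter), which does not separate it from oxolan-3-yl, yet a number 11 percentage points lower from compound 1 to compound 4 (beyond the scatter), which does separate it from cyclopentyl. No measurement at hand explains any of these differences.

Open, going by these compounds, is whether the higher number belongs to aromatic rings at this position in general or to 1-methyl-1H-pyrazol-4-yl alone, a question that a phenyl or a pyridin-3-yl on the same carbon would address. Also open, on these data alone, are the part played by the defined stereocentre of compound 4, which its mirror-image form would test, and the outcome with a ring carrying an amine, such as pyrrolidin-3-yl, or with an open chain such as isopropyl.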